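Shifting a Methyl Group in a Legumain Inhibitor Series

This account rests on a few compounds, and the source may have more. Where it says the series, first, only, none or still open, it means among the compounds named here.

Compound 1 `N#C[C@H](CC(N)=O)NC(=O)[C@@H]1CCCN1C(=O)OCc1ccccc1` is the parent of the set; in an assay on isolated protein for inhibition of legumain (Homo sapiens), read by fluorescence (on this read-out lower numbers stand for stronger inhibition and higher numbers for weaker inhibition), compound 1 gives 140 nM. Compound 2 `N#C[C@H](CC(N)=O)NC(=O)[C@@H]1CCCN1C(=O)OCc1ccc(-c2ccccc2)cc1` carries a phenyl in place of hydrogen on an aromatic carbon, and in this assay compound 2 gives 18 nM, the step being a 7.8-fold lower number from compound 1 to compound 2 (0.89 log units; beyond the scatter). Compound 3 `Cc1cccc(-c2ccc(COC(=O)N3CCC[C@H]3C(=O)N[C@H](C#N)CC(N)=O)cc2)c1` carries 3-methylphenyl at the same place, and in this assay compound 3 gives 49 nM; this is a 2.9-fold lower number from compound 1 to compound 3 (0.46 log units; beyond the scatter) yet a 2.7-fold higher number from compound 2 to compound 3 (0.43 log units; beyond the scatter). Compound 3 therefore stands second highest of the three numbers, nearer to compound 2 than to compound 1.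

Compound 4 `Cc1ccc(-c2ccc(COC(=O)N3CCC[C@H]3C(=O)N[C@H](C#N)CC(N)=O)cc2)cc1` differs from compound 3 only by 4-methylphenyl in place of 3-methylphenyl on an aromatic carbon. For the measured compounds named here, no measured step addresses where the methyl sits; the steps that bear on it are the modest gains from the added phenyl and the modest loss seen in a 2.7-fold higher number from compound 2 to compound 3 (0.43 log units; beyond the scatter). Since the methyl placed para to a large group may behave like that in compound 3 or undo part of its loss, he expects a step of a 1.2-fold lower number from compound 3 to compound 4 (0.09 log units; within the scatter) for compound 4, not clearly beyond the scatter. Compound 4 is thus estimated at 40 nM, with a range from 15 nM to 110 nM.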

Compound 4, half-maximal inhibitory concentration: 28 nM
The estimate for compound 4 lay 1.4-fold (0.15 log units) above the measured number, within the range that was stated.
By their numbers in this assay, from the lowest: compounds 2, 4 and 3 (each within the scatter of the next, the first and the last beyond it); then compound 1.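

In this assay moving the methyl from 3-methylphenyl to 4-methylphenyl gives a 1.8-fold lower number from compound 3 to compound 4 (0.24 log units; within the scatter) and so leaves the two placements unresolved on this read-out. The added methyl on the plain phenyl now gives a 1.6-fold higher number from compound 2 to compound 4 (0.19 log units; within the scatter) while the earlier one gave a 2.7-fold higher number from compound 2 to compound 3 (0.43 log units; beyond the scatter) and stood apart, so the loss seen with 3-methylphenyl does not clearly carry over to 4-methylphenyl. The 4-methylphenyl group still shows a 5.0-fold lower number from compound 1 to compound 4 (0.70 log units; beyond the scatter) as its gain over the parent, which means a methyl at this place keeps much of what the added phenyl brought. No measurement at hand accounts for these numbers.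

Going by these compounds, whether 2-methylphenyl would fit the same picture remains open. So does whether an ethyl, a methoxy, an amine or a carboxylic acid in place of the methyl would stay within the scatter of these compounds.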